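This account rests on a few compounds, and the source may have more. Where it says the series, first, only, none or still open, it means among the compounds named here.

Of the compounds shown here, two have so far been measured in an assay on isolated protein for inhibition of DNA topoisomerase 1 (Homo sapiens), with a stated time of 30 min, tested at 20 uM; a lower number here means a weaker effect, a higher number a stronger effect of the compound at the concentration tested. Compound 1 `Cc1ccc2nc(-c3ccccc3N(C)C)[nH]c(=O)c2c1` gives 21.1%. Compound 2 `CCN(CC)c1ccc2nc(-c3ccccc3OC(F)(F)F)[nH]c(=O)c2c1` gives 0%, the lower of the two numbers, and its gap to compound 1 lies beyond the usual scatter. Both share one core: compound 1 carries a methyl on it and a dimethylamino on the six-membered aromatic ring of carbon only, while compound 2 carries a diethylamino on the core and a trifluoromethoxy on that ring. Compound 3 `CCN(CC)c1ccc2nc(-c3ccccc3N(C)C)[nH]c(=O)c2c1` keeps the diethylamino of compound 2 and alters the ring: dimethylamino in place of trifluoromethoxy on an aromatic carbon. For the measured compounds named here, no single-change step between measured compounds exists to guide the size, so the expectation rests on compound 1, the only measured compound bearing the dimethylamino. A modest rise is expected, a number 12 percentage points higher from compound 2 to compound 3 (beyond the scatter), in this assay. Compound 3 is estimated to give 12%, between 0% and 30%, because compound 1 with the same dimethylamino gives 21.1%.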

Compound 3, a percentage reported as inhibition, at one concentration (the size of the read-out at that concentration, not a potency): 0%
The estimate for compound 3 lay 12 percentage points above the measured number; the measured number falls inside the stated range.
By their numbers in this assay, from the lowest: compounds 2 and 3 (each within the scatter of the next); then compound 1.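

In this assay, trading the group on the six-membered aromatic ring of carbon only leaves no mark, with no change at the digits printed from compound 2 to compound 3 (within the scatter), so alongside the diethylamino these two groups cannot be told apart. Both compounds sit at the bottom of the read-out, which means a difference between the two groups could stay hidden with the diethylamino in place. For the compounds shown here, the other pair keeps the dimethylamino fixed and changes only the group on the core, and there the effect is lost, with a number 21.1 percentage points lower from compound 1 to compound 3 (beyond the scatter), which is the first direct sign that this place matters.

Still open, as far as these compounds go, is how a methoxy, a primary amine or a carboxylic acid would read in that place on the core, and whether trifluoromethoxy would differ from dimethylamino with a methyl on the core. Nothing measured here explains these numbers.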